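The compounds below may be only part of what the source reports. "The series", "measured", "known", "first", "only" and "open" are said of these compounds alone.

Measured so far in a physicochemical assay for lipophilicity, at pH 7.4; on this read-out higher numbers stand for higher lipophilicity and lower numbers for lower lipophilicity:
compound 1 `CN1C(=O)[C@@H](NC(=O)c2nnn3c2C[C@H](C(F)(F)F)CC3)COc2ccccc21` gives 1.5
compound 2 `CN1C(=O)[C@@H](NC(=O)c2n[nH]c3ncc(C(F)(F)F)cc23)COc2ccccc21` gives 3.3

Compound 2 stands highest of the two at 3.3 and compound 1 lies lower at 1.5 with a gap beyond the usual scatter. Compound 3 `CC(C)c1cnc2[nH]nc(C(=O)N[C@H]3COc4ccccc4N(C)C3=O)c2c1` follows from compound 2 with isopropyl in place of trifluoromethyl on an aromatic carbon. Within the data shown here, compound 1 and compound 2 differ in more than one place, so the series offers no single-change step as a guide. In this assay the expectation is a small rise from compound 2, perhaps none beyond the scatter. The expected step is a number 0.10 log units higher from compound 2 to compound 3 (within the scatter) and it rests only on the exchange of these two groups. Compound 3 is estimated at 3.4 with an expected range from 3 to 3.8 on this read-out.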

Compound 3, distribution coefficient: 3.5
Compound 3: the middle estimate sits 0.10 log units below what was measured; the measured number falls inside the stated range.
By their numbers in this assay, from the lowest: compound 1; then compounds 2 and 3 (each within the scatter of the next).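

In this assay, among these compounds, isopropyl in place of trifluoromethyl on this aromatic carbon gives a number 0.20 log units higher from compound 2 to compound 3 (within the scatter), the first single-change step. On this read-out, the two groups cannot be told apart at this position of the shared core, despite the exchange of a carbon bearing three fluorine atoms for a purely carbon group. No available evidence bears on this result.

Open, from the compounds shown here alone, is whether a group of another kind on this aromatic carbon, such as an amine, a carboxylic acid or a longer alkyl chain, would give a step beyond the scatter in this assay. Also open, going by these compounds, is whether the same exchange would read alike elsewhere, for instance on the core of compound 1, where the trifluoromethyl group sits on a non-aromatic carbon.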